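Swapping the dichlorinated quinoline for a bare quinoline

The source may hold more compounds than are shown below. What is called first, only, known or untested is meant among the compounds shown, and "the series" means these compounds.

Of the compounds shown here, three sharing a common core have been tested in an ADME assay on SNB-19 cells (Homo sapiens) for cytotoxicity, read by MTT assay, with a stated time of 24 h; a lower number here means that less compound is tolerated, a higher number that more compound is tolerated. Compound 1 `C=C1CC[C@H]2[C@@](C)(CCC(=O)[C@@]2(C)COC(C)=O)[C@@H]1C/C=C1/C(=O)OC[C@@H]1Oc1cccc2ccc(C)nc12` gives 51700 nM, compound 3 `C=C1CC[C@@H]2[C@](C)(CO)[C@H](O)CC[C@@]2(C)[C@@H]1C/C=C1/C(=O)OC[C@@H]1Oc1ccnc2ccccc12` gives 61200 nM, and compound 2 `C=C1CC[C@H]2[C@@](C)(CCC(=O)[C@@]2(C)COC(C)=O)[C@@H]1C/C=C1/C(=O)OC[C@@H]1Oc1c(Cl)cc(Cl)c2cccnc12` gives 72000 nM; the three numbers all lie within the usual scatter of one another, so compound 2 does not stand apart from either neighbour. Compound 4 `C=C1CC[C@H]2[C@@](C)(CCC(=O)[C@@]2(C)COC(C)=O)[C@@H]1C/C=C1/C(=O)OC[C@@H]1Oc1cccc2cccnc12` has not yet been measured; it differs from compound 2 by quinolin-8-yl in place of 5,7-dichloroquinolin-8-yl on an oxygen on a saturated carbon. Among the measured compounds shown here, the one comparable change already seen, a different group on the same oxygen, gave a 1.4-fold higher number from compound 1 to compound 2 (0.14 log units; within the scatter). Since that step stayed within the scatter, the estimate for compound 4 is a step of a 1.2-fold lower number from compound 2 to compound 4 (0.09 log units; within the scatter), essentially none. Compound 4 is therefore expected to give 58000 nM, within a range of 30000 nM to 110000 nM.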

Compound 4, half-maximal cytotoxic concentration: 21900 nM
For compound 4 the middle estimate is 2.6-fold (0.42 log units) above the measured one; measured number below the stated range.
By their numbers in this assay, from the lowest: compound 4; then compounds 1, 3 and 2 (each within the scatter of the next).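

The group on this oxygen matters more than compounds 1 and 2 suggested: in this assay the bare quinolin-8-yl stands apart from both substituted versions. Removing the two chlorines gives a 3.3-fold lower number from compound 2 to compound 4 (0.52 log units; beyond the scatter) and removing the methyl gives a 2.4-fold lower number from compound 1 to compound 4 (0.37 log units; beyond the scatter), so among these three compounds, either kind of substituent goes with more compound being tolerated than the bare group. Nothing measured here explains this difference. Still open, going by these compounds, is whether a single chlorine would have the same effect, and how an amine or a methoxy group on the quinolin-8-yl would compare.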